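Halogen swap on the aryl ring and microsomal half-life

The source may hold more compounds than are shown below. What is called first, only, known or untested is meant among the compounds shown, and "the series" means these compounds.

Compound 1 `Nc1nc(NCCNc2ncc(-c3ncc[nH]3)c(-c3ccccc3Cl)n2)ccc1[N+](=O)[O-]`, compound 2 `Nc1nc(NCCNc2ncc(-c3ncc[nH]3)c(-c3ccccc3Br)n2)ccc1[N+](=O)[O-]` and compound 3 `Nc1nc(NCCNc2ncc(-c3ncc[nH]3)c(-c3ccc(Cl)cc3F)n2)ccc1[N+](=O)[O-]` share a core and differ only in the aryl group on it. In an ADME assay on microsomes from liver (Rattus norvegicus) for metabolic stability (on this read-out lower numbers stand for a shorter-lived compound and higher numbers for a longer-lived compound), compound 1 gives > 0.5 h, which is a limit of the assay. In this assay compound 2 gives > 0.5 h, also a limit. In this assay compound 3 gives > 0.5 h, again a limit. The change bromo in place of chloro on an aromatic carbon makes a step that the two limits leave unreadable from compound 1 to compound 2; every value sits at the limit of > 0.5 h in this assay, at which 3 of the 3 values shown sit. The cores of compound 1 and compound 3 differ by 4-chloro-2-fluorophenyl in place of 2-chlorophenyl on an aromatic carbon. Compound 4 `Nc1nc(NCCNc2ncc(-c3ncc[nH]3)c(-c3ccc(Br)cc3F)n2)ccc1[N+](=O)[O-]` carries the same kind of change as compound 2, (bromo in place of chloro on an aromatic carbon), though the place differs: meta to a fluoro group and para to a large group rather than ortho to a large group. From compound 3 to compound 4 a step that the limit leaves unreadable from compound 3 to compound 4 is expected, resting on compound 1 at the limit of > 0.5 h in this assay, at which 3 of the 3 values shown sit, and on a step that the two limits leave unreadable from compound 1 to compound 2. Compound 4 is estimated at 1 h.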

Compound 4, half-life: > 0.5 h
Compound 4: no number, only a limit; the forecaster's own chance of this, stated with the estimate: 80%; the middle value does not contradict the limit.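

No step from compound 4 to compound 1, compound 2 or compound 3 can be read, as all four values are limits: the limit of > 0.5 h in this assay, at which 4 of the 4 values shown sit.

The compounds shown leave open what the actual half-lives are and whether bromo in place of chloro changes them at either place.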